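A few compounds are considered here, and "the series" means these few. Any claim that something is new, unique, unknown or untested is made for them only; others in the source may bear on it.

Compound 2 `COc1cccc2c1CCC(=O)N2CCCN1CCN(c2cccc(C(F)(F)F)c2)CC1` gives 490 nM in an assay on cell membranes for binding affinity to Sigma non-opioid intracellular receptor 1 (Rattus norvegicus); a higher number here means a weaker inhibitor, a lower number a stronger inhibitor. Compound 1 `COc1ccc2c(c1)CCC(=O)N2CCCN1CCN(c2cccc(Cl)c2)CC1` gives 650 nM in this assay, and the two values lie within the scatter of each other, so neither stands apart from the other. Compound 3 `COc1cccc2c1CCC(=O)N2CCCN1CCN(c2cccc(C#N)c2)CC1` differs from compound 2 in one place: cyano in place of trifluoromethyl on an aromatic carbon. Within the data shown here, no measured pair shows this change, so its effect is not known from the data. On the numbers alone, a small step toward a higher number, possibly not beyond the scatter, is expected in this assay. Compound 3 is estimated at 900 nM, with a range from 300 nM to 2500 nM. The expected change is a 1.8-fold higher number from compound 2 to compound 3 (0.26 log units; within the scatter).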

Compound 3, half-maximal inhibitory concentration: 2470 nM
For compound 3 the middle estimate is 2.7-fold (0.44 log units) below the measured one; low and high end bracket the measured number.
By their numbers in this assay, from the lowest: compounds 2 and 1 (each within the scatter of the next); then compound 3.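

In this assay, exchanging 3-(trifluoromethyl)phenyl for 3-cyanophenyl on the shared core gives a 5.0-fold higher number from compound 2 to compound 3 (0.70 log units; beyond the scatter). Among these compounds, this is the first single-place comparison, and it shows that the group on this aromatic carbon affects the read-out, with the cyano compound the weaker inhibitor. Nothing available accounts for this loss. On these data alone, it remains open whether other groups at this place, such as an amine or a carboxylic acid, would follow compound 3 or stay close to compound 2. As far as these compounds go, whether the same exchange carries the same size on the core of compound 1 is also open.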